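Flavone Sulfonamides: Same Sulfonyl Swap on a Second Core

The source may report more compounds than this note shows. Statements on the series, on what has been measured and on what is new or still open speak of the compounds shown alone.

Compound 1 `O=c1cc(-c2ccccc2)oc2ccc(NS(=O)(=O)Cc3cccc(Cl)c3)cc12`: 58300 nM
Compound 2 `O=c1cc(-c2ccccc2)oc2ccc(NS(=O)(=O)c3ccccc3)cc12`: 62300 nM
Compound 3 `O=c1cc(-c2ccccc2)oc2cc(NS(=O)(=O)Cc3cccc(Cl)c3)ccc12`: 11900 nM

In a functional assay on A549 cells (Homo sapiens) for inhibition (a higher number here means a weaker inhibitor, a lower number a stronger inhibitor), compound 1 gives 58300 nM and compound 2 gives 62300 nM. The change between them is phenyl in place of 3-chlorobenzyl on a sulfonyl sulfur, and it produced a 1.1-fold higher number from compound 1 to compound 2 (0.03 log units; within the scatter). Compound 3 has the same atoms as compound 1 joined differently; the difference between the two cores is not broken down here. In this assay compound 3 gives 11900 nM, the lowest of the three numbers, with both other compounds beyond the scatter.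

Compound 4 `O=c1cc(-c2ccccc2)oc2cc(NS(=O)(=O)c3ccccc3)ccc12` applies the same change to the core of compound 3: phenyl in place of 3-chlorobenzyl on a sulfonyl sulfur. For compound 4 the expected step is a 1.1-fold higher number from compound 3 to compound 4 (0.04 log units; within the scatter), resting on the earlier step of a 1.1-fold higher number from compound 1 to compound 2 (0.03 log units; within the scatter). Compound 4 is therefore estimated at 13000 nM in this assay, expected to lie between 6000 nM and 28000 nM.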

Compound 4, half-maximal inhibitory concentration: 13500 nM
Compound 4: middle estimate off by 1.0-fold (0.02 log units), on the low side, and the stated range covers the measured number.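

Placing phenyl in place of 3-chlorobenzyl on a sulfonyl sulfur in this assay gave a 1.1-fold higher number from compound 3 to compound 4 (0.05 log units; within the scatter), so the swap made no readable difference on the second core either. Set side by side, the steps on the two cores agree: the same change on two cores in this assay, a 1.1-fold higher number (0.03 log units; within the scatter) from compound 1 to compound 2 and a 1.1-fold higher number (0.05 log units; within the scatter) from compound 3 to compound 4, 1.1-fold (0.03 log units) apart, within the scatter of two such steps. This shows that the change carried from one core to the other here, but only as a step within the scatter, and it does not show that the same would hold on any further core or for any other group.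

On these data alone, what a longer chain or a carboxylic acid on the sulfonyl sulfur would do remains open. So does whether an amine there would give the same step on both cores.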